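The compounds below may be only part of what the source reports. "The series", "measured", "known", "first", "only" and "open" are said of these compounds alone.

The measured compounds:
compound 1 `O=S(=O)(NCC1CCN(CCCc2c[nH]c3ccc(-n4cnnc4)cc23)CC1)c1ccccc1`: 12 nM
compound 2 `COC[C@H](NC1CCN(CCCc2c[nH]c3ccc(-n4cnnc4)cc23)CC1)c1ccccc1`: 0.9 nM
compound 3 `c1ccc2c(c1)CCC2NC1CCN(CCCc2c[nH]c3ccc(-n4cnnc4)cc23)CC1`: 25 nM

In an assay on CHO cells for agonist activity at 5-hydroxytryptamine receptor 1D (Homo sapiens), read by GTPgammaS binding (on this read-out higher numbers stand for an effect only at larger amounts of compound and lower numbers for an effect already at smaller amounts), compound 2 gives 0.9 nM, the lowest of the three numbers. The step of a 13-fold lower number from compound 1 to compound 2 (1.12 log units; beyond the scatter) and the step of a 28-fold higher number from compound 2 to compound 3 (1.44 log units; beyond the scatter) both lie beyond the scatter, so compound 2 is the most potent compound measured here. Compound 4 `C[C@@H](NC1CCN(CCCc2c[nH]c3ccc(-n4cnnc4)cc23)CC1)c1ccccc1` differs from it in one place: 1-phenylethyl in place of 2-methoxy-1-phenylethyl on an amine nitrogen. Two measured steps alter the same substituent on the amine nitrogen. The step of a 28-fold higher number from compound 2 to compound 3 (1.44 log units; beyond the scatter) exchanges the whole group for 2,3-dihydro-1H-inden-1-yl, and the step of a 13-fold lower number from compound 1 to compound 2 (1.12 log units; beyond the scatter) reaches compound 2 from a side chain carrying a phenylsulfonyl group. Neither removes only the methoxy while keeping the phenyl and the stereocentre, so the effect of that smaller change is not directly shown. The two steps do show that this assay responds strongly to what sits on this nitrogen, and that 2-methoxy-1-phenylethyl is the best of the three groups tried. Losing the methoxy is therefore expected to cost some activity, though less than the exchange seen in compound 3. For compound 4 the estimated step is a 3.3-fold higher number from compound 2 to compound 4 (0.52 log units; beyond the scatter). Compound 4 is expected to give 3 nM, within 1 nM to 10 nM.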

Compound 4, half-maximal effective concentration: 13 nM
Beside the measured number, compound 4's estimate is 4.3-fold (0.64 log units) below it; the measured number lies above the stated range.
By their numbers in this assay, from the lowest: compound 2; then compounds 1, 4 and 3 (each within the scatter of the next, the first and the last beyond it).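

In this assay, the methoxy of 2-methoxy-1-phenylethyl on the amine nitrogen proves to matter far more than the earlier compounds could show: with the phenyl ring and a defined stereocentre still present, its loss gives a 14-fold higher number from compound 2 to compound 4 (1.16 log units; beyond the scatter) and so accounts for a large share of what sets compound 2 apart. The 1-phenylethyl group alone has no such standing, since a 1.9-fold lower number from compound 3 to compound 4 (0.28 log units; within the scatter) and a 1.1-fold higher number from compound 1 to compound 4 (0.03 log units; within the scatter) both remain within the scatter, so the position of compound 2 rests on the complete 2-methoxy-1-phenylethyl group and not on its phenyl-bearing frame. Nothing available here explains why the methoxy has so large an effect on this read-out.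

As far as these compounds go, it remains open whether the oxygen itself is what counts, which a hydroxymethyl group, an ethoxymethyl group or a longer ether chain in place of the methoxymethyl part could test. Also open, from the compounds shown here alone, is whether the methoxy keeps its effect with the opposite configuration at the stereocentre, or with a pyridine ring in place of the phenyl ring.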